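Ester aryl series: nitro for chloro on the ester ring

The compounds below may be only part of what the source reports. "The series", "measured", "known", "first", "only" and "open" are said of these compounds alone.

In a functional assay on SK-LU-1 cells (Homo sapiens) for antiproliferative activity, read by sulforhodamine B assay, with a stated time of 48 h, tested at 50 uM (on this read-out lower numbers stand for less inhibition and higher numbers for more inhibition at the one concentration tested (going by the name of the read-out)), compound 1 `COc1ccc(C(=O)Oc2cc3c(cc2C)[C@@H](C(C)C)CC=C3C)cc1` gives 18.6% and compound 2 `CC1=CC[C@H](C(C)C)c2cc(C)c(OC(=O)c3ccc(Cl)cc3)cc21` gives 17.4%; the step of a number 1.2 percentage points lower from compound 1 to compound 2 (within the scatter) corresponds to chloro in place of methoxy on an aromatic carbon. For compound 3 `CC1=CC[C@H](C(C)C)c2cc(C)c(OC(=O)c3ccc(C(F)(F)F)cc3)cc21` the result is recorded as "not active" (no number reported), with no number attached. Compound 2 therefore stands level with compound 1 within the scatter, with one further entry carrying no number. Compound 4 `CC1=CC[C@H](C(C)C)c2cc(C)c(OC(=O)c3cccc([N+](=O)[O-])c3)cc21` differs from compound 2 by 3-nitrophenyl in place of 4-chlorophenyl on a carbonyl carbon. Among the compounds with values here, only the step from compound 1 to compound 2 bears on changes to the ester ring, and it stayed within the scatter, so no movement beyond the scatter is expected in this assay. Compound 4 is expected to give 15% in this assay, in the range 2% to 30%. The expected step is thus a number 2.4 percentage points lower from compound 2 to compound 4 (within the scatter), inside the scatter.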

Compound 4, a percentage reported as inhibition, at one concentration (the size of the read-out at that concentration, not a potency): 60.4%
The estimate for compound 4 lay 45.4 percentage points below the measured number; measured number above the stated range.
By their numbers in this assay, from the lowest: compounds 2 and 1 (each within the scatter of the next); then compound 4.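

In this assay 3-nitrophenyl in place of 4-chlorophenyl on the carbonyl carbon gives a number 43 percentage points higher from compound 2 to compound 4 (beyond the scatter) and 3-nitrophenyl in place of 4-methoxyphenyl gives a number 41.8 percentage points higher from compound 1 to compound 4 (beyond the scatter) at the same place. This carbonyl carbon substituent can therefore shift the read-out beyond the scatter, which the step between compound 1 and compound 2 did not show. Nothing at hand accounts for this difference.

The group and its ring numbering change together in these steps, so the contribution of each stays unresolved. A 3-chlorophenyl or 4-nitrophenyl group on the same carbonyl carbon would separate the two.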